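This account rests on a few compounds, and the source may have more. Where it says the series, first, only, none or still open, it means among the compounds named here.

Measured so far:
- compound 1 `O=C1/C(=C/c2ccccc2F)CN(C(=S)SCc2cn(Cc3ccccc3F)nn2)C/C1=C\c1ccccc1F`: 57600 nM
- compound 2 `O=C1/C(=C/c2ccccc2F)CN(C(=S)SCc2cn(Cc3ccc(F)cc3)nn2)C/C1=C\c1ccccc1F`: 58800 nM

Both values come from a functional assay on MDA-MB-231 cells (Homo sapiens) for cytotoxicity, read by MTT assay, with a stated time of 24 h; on this read-out lower numbers stand for stronger inhibition and higher numbers for weaker inhibition. Within the data shown here, compound 2 stands at 58800 nM, and the only other measured value lies within the usual scatter of it, so the two cannot be ranked.

Compound 3 `O=C1/C(=C/c2ccccc2F)CN(C(=S)SCc2cn(Cc3cccc(Cl)c3)nn2)C/C1=C\c1ccccc1F` differs from compound 2 in one place: 3-chlorophenyl in place of 4-fluorophenyl on a saturated chain carbon bound to an aromatic nitrogen. In words, this is 3-chlorophenyl in place of 4-fluorophenyl on a saturated chain carbon bound to an aromatic nitrogen, or 4-fluorobenzyl to 3-chlorobenzyl.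

Among the measured compounds shown here, one measured step bears on this place. That step, a 1.0-fold higher number from compound 1 to compound 2 (0.01 log units; within the scatter), exchanged 2-fluorophenyl for 4-fluorophenyl and stayed within the scatter. For the measured compounds named here, no measured compound carries 3-chlorophenyl, so the data say nothing about that group directly. In this assay, no step beyond the scatter is therefore expected, and neither direction is favoured. The estimated step is a 1.1-fold lower number from compound 2 to compound 3 (0.03 log units; within the scatter). The expected value for compound 3 is 55000 nM, with an estimated range of 29000 nM to 100000 nM.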

Compound 3, half-maximal inhibitory concentration: > 100000 nM
Compound 3: only a limit was reported (the forecaster's own chance of this, stated with the estimate: 8%); middle value at least 1.8-fold (0.25 log units) away from the limit.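

In this assay, compound 3 gives > 100000 nM, which is a limit of the assay and not a number. At this position, the 2-fluorophenyl and 4-fluorophenyl groups had given values that could not be ranked, whereas 3-chlorophenyl is the only group shown that reaches the limit, with an at least 1.7-fold higher number from compound 2 to compound 3 (0.23 log units; that floor lies within the scatter) and an at least 1.7-fold higher number from compound 1 to compound 3 (0.23 log units; that floor lies within the scatter). This adds a first sign that the group on this saturated chain carbon may matter in this assay, but it is no more than a sign, since each step is only a floor and the true distance of compound 3 from the other two stays unknown: the limit of > 100000 nM in this assay, at which 1 of the 3 values shown sits.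

The compounds shown leave open whether the change in the halogen or the change in its place on the ring goes with this result, a question that 3-fluorophenyl and 4-chlorophenyl groups would separate. They also leave open how an unsubstituted phenyl ring, a methoxy group or a dimethylamino group on the ring would read out at this position.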